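A few compounds are considered here, and "the series" means these few. Any claim that something is new, unique, unknown or untested is made for them only; others in the source may bear on it.

The measured compounds, each in the same assay:

Compound 1 `O=C(CCCCOc1ccccc1)OCC1COCCOCCOCCOCCOCCO1` — in a functional assay on SW1573 cells (Homo sapiens) for inhibition, read by sulforhodamine B assay, with a stated time of 48 h (a lower number here means a stronger inhibitor of growth, a higher number a weaker inhibitor of growth), compound 1 gives > 100000 nM, a limit of the assay and not a number.
Compound 2 `CC/C=C/CC(=O)OCC1COCCOCCOCCOCCOCCO1` — in this assay compound 2 gives > 100000 nM, again a limit rather than a number.
Compound 3 `O=C(CCCCc1ccccc1)OCC1COCCOCCOCCOCCOCCO1` — in this assay compound 3 gives > 100000 nM, also a limit.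

Compound 3 therefore stands at the limit, and it shares that position with every other measured compound, since (the limit of > 100000 nM in this assay, at which 3 of the 3 values shown sit). The three steps among the measured compounds, a step that the two limits leave unreadable from compound 1 to compound 2, a step that the two limits leave unreadable from compound 1 to compound 3 and a step that the two limits leave unreadable from compound 2 to compound 3, are all unreadable in size because of the limit of > 100000 nM in this assay, at which 3 of the 3 values shown sit.

The next compound, compound 4 `O=C(OCC1COCCOCCOCCOCCOCCO1)c1cccnc1`, differs from compound 3 in the acid portion of the ester: pyridin-3-yl in place of 4-phenylbutyl on a carbonyl carbon. Going by the values given here, the steps that bear on this change are the exchanges of the acid portion already made, from compound 1 to compound 3 and from compound 2 to compound 3, and neither gives a readable size. Among the compounds with values here, there is thus no measured step on which a shift in either direction could rest, and none beyond the scatter is expected in this assay.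

Compound 4 is accordingly estimated at 150000 nM in this assay, with a range from 50000 nM to 500000 nM. This corresponds to an expected step that the limit leaves unreadable from compound 3 to compound 4, most likely reported again as a limit.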

Compound 4, concentration for 50% growth inhibition: > 100000 nM
Compound 4 gave a limit, no number; the forecaster's own chance of this, stated with the estimate: 85%; the middle value lies beyond the limit too.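

The steps from compound 1, compound 2 and compound 3 to compound 4 cannot be read in size, since all four compounds give a limit and not a number: the limit of > 100000 nM in this assay, at which 4 of the 4 values shown sit. The compounds shown leave open whether any of these acid portions, pyridin-3-yl included, changes growth inhibition in this assay at all, and how the four compounds would rank.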